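From dimethylamino to (3-bromophenyl)amino on a shared core

A few compounds are considered here, and "the series" means these few. Any claim that something is new, unique, unknown or untested is made for them only; others in the source may bear on it.

compound 1 `CCCc1nn(C)c2c(NC(C)C)nc(/C=C/c3ccc[n+]([O-])c3)nc12`: 324000 nM
compound 2 `CN(C)c1nc(/C=C/c2ccccc2)nc2ccsc12`: > 1000000 nM

In a functional assay on L02 cells (Homo sapiens) for inhibition, read by Griess assay, with stated times of 1 h and 24 h (on this read-out higher numbers stand for weaker inhibition and lower numbers for stronger inhibition), compound 1 gives 324000 nM. For compound 2 the result is only a limit, > 1000000 nM; this is the limit of > 1000000 nM in this assay, at which 1 of the 2 values shown sits. Compound 3 `Brc1cccc(Nc2nc(/C=C/c3ccccc3)nc3ccsc23)c1` carries (3-bromophenyl)amino in place of dimethylamino on an aromatic carbon. Among the measured compounds shown here, no step between two measured compounds is available, so nothing measured tells the size of such a change; the expectation is that it stays within the usual scatter of this assay. Compound 3 is therefore estimated at 700000 nM, in a range from 200000 nM to 3000000 nM, meaning an expected step of an at least 1.4-fold lower number from compound 2 to compound 3 (0.15 log units; that floor lies within the scatter).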

Compound 3, half-maximal inhibitory concentration: > 1000000 nM
Compound 3 gave a limit, no number; the forecaster's own chance of this, stated with the estimate: 50%; at least 1.4-fold (0.15 log units) between middle value and limit.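

Compound 2 and compound 3 both gave only limits, so no step between them can be read: the limit of > 1000000 nM in this assay, at which 2 of the 3 values shown sit.

The compounds shown leave open how far (3-bromophenyl)amino in place of dimethylamino on the shared core changes inhibition.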